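The compounds below may be only part of what the source reports. "The series", "measured", "known", "first", "only" and "open" are said of these compounds alone.

Measured in a functional assay on P388 cells (Mus musculus) for cytotoxicity; on this read-out lower numbers stand for stronger inhibition and higher numbers for weaker inhibition:
- compound 1 `Cc1cc(-c2c(F)cc3c(=O)c(Cc4ccccc4)cn(C4CC4)c3c2F)cc(C)n1`: 7300 nM
- compound 2 `Cc1cc(-c2c(F)cc3c(=O)c(C(=O)O)cn(C4CC4)c3c2F)cc(C)n1`: 29000 nM
- compound 3 `Cc1cc(-c2c(F)cc3c(=O)c(Cc4ncc[nH]4)cn(C4CC4)c3c2F)cc(C)n1`: 1100 nM

Compound 3 has the lowest number of the three, and the next step leads from it to compound 4 `Cc1cc(-c2c(F)cc3c(=O)c(Cc4c(O)cc(O)cc4O)cn(C4CC4)c3c2F)cc(C)n1`. The change is 2,4,6-trihydroxyphenyl in place of 1H-imidazol-2-yl on a saturated chain carbon bound to an aromatic carbon, with 2,4,6-trihydroxyphenyl in place of 1H-imidazol-2-yl on a saturated chain carbon bound to an aromatic carbon. The most relevant measurement is a 6.6-fold lower number from compound 1 to compound 3 (0.82 log units; beyond the scatter), a modest step in which 1H-imidazol-2-yl took the place of phenyl at that same carbon. Among the compounds with values here, compound 4 returns to a six-membered aromatic ring of carbon only, so part of that step may be undone, although no measured compound shows what the hydroxy groups do. The large 26-fold lower number from compound 2 to compound 3 (1.42 log units; beyond the scatter) bears less directly, since it starts from carboxy on an aromatic carbon. A modest rise is therefore expected, and the estimate is a 2.3-fold higher number from compound 3 to compound 4 (0.36 log units; beyond the scatter). For compound 4 the expected value is 2500 nM, with an estimated range from 500 nM to 10000 nM.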

Compound 4, half-maximal inhibitory concentration: 470 nM
Beside the measured number, compound 4's estimate is 5.3-fold (0.73 log units) above it; measured number below the stated range.
By their numbers in this assay, from the lowest: compound 4; then compound 3; then compound 1; then compound 2.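

In this assay, within the data shown here, an all-carbon aromatic ring at this saturated chain carbon proves compatible with the lowest number so far, as a 2.3-fold lower number from compound 3 to compound 4 (0.37 log units; beyond the scatter) moves past the 1H-imidazol-2-yl compound rather than back towards the benzyl compound. Placing 2,4,6-trihydroxyphenyl on that carbon instead of phenyl gives a 16-fold lower number from compound 1 to compound 4 (1.19 log units; beyond the scatter) and so separates two compounds with the same kind of ring, showing that the substituents on the ring matter at this position. Against the carboxy compound the change reaches a 62-fold lower number from compound 2 to compound 4 (1.79 log units; beyond the scatter) and is the widest gap in the set, while no available evidence accounts for these differences.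

Open, from the compounds shown here alone, is whether a single hydroxy group on the benzyl ring would do as much as the three in 2,4,6-trihydroxybenzyl, or whether methoxy groups in their place would keep the low number. Also open, going by these compounds, is whether a longer chain carrying the same ring would hold the gain.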